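The source may report more compounds than this note shows. Statements on the series, on what has been measured and on what is new or still open speak of the compounds shown alone.

Of the compounds shown here, two have been measured in an ADME assay on HepG2 cells (Homo sapiens) for cytotoxicity, with a stated time of 72 h; a higher number here means that more compound is needed for the effect, a lower number that less compound is needed. Compound 1 `COC(=O)C1CCN(c2cc(Cl)c(C(=O)Nc3cc(-c4nc5ccccc5s4)ccc3C)cc2[N+](=O)[O-])CC1` gives > 25000 nM, which is a limit of the assay and not a number. Compound 2 `COc1ccc(-c2nc3ccccc3s2)cc1NC(=O)c1cc([N+](=O)[O-])ccc1Cl` gives > 25000 nM, which is also a limit and not a number. Compound 2 therefore stands at the limit of > 25000 nM in this assay, at which 2 of the 2 values shown sit, and no exact value is known for it.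

The next compound, compound 3 `Cc1ccc(-c2nc3ccccc3s2)cc1NC(=O)c1cc([N+](=O)[O-])ccc1Cl`, alters a single group of compound 2: methyl in place of methoxy on an aromatic carbon. This puts methyl in place of methoxy on an aromatic carbon, para to a 1,3-benzothiazol-2-yl group. Within the data shown here, no measured pair shows what this swap does in this assay, so the expectation rests on compound 2 with its limit of > 25000 nM. No step beyond the usual scatter is expected in either direction, and the estimated step is a step that the limit leaves unreadable from compound 2 to compound 3. For compound 3 the expected value is 30000 nM, with an estimated range from 12000 nM to 60000 nM. The most likely outcome is that the assay again reports only a limit.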

Compound 3, half-maximal effective concentration: > 14000 nM
Compound 3 was reported as a limit; the forecaster's own chance of this, stated with the estimate: 85%; the middle value does not contradict the limit.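

All three results in this assay are limits of the assay and not numbers, so the steps from compound 2 to compound 3 and from compound 1 to compound 3 cannot be read. The compounds shown leave open what exact concentration each one needs for the effect, and whether swapping methoxy for methyl changes it at all.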